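Solubility notes: pyridin-4-yl replacing 4-methoxyphenyl on the core

The source may hold more compounds than are shown below. What is called first, only, known or untested is meant among the compounds shown, and "the series" means these compounds.

Measured so far:
compound 1 `Cc1cccc(CNc2cc(C)nc3c(-c4ccccc4)c(C)nn23)n1`: in a physicochemical assay for solubility, read by HPLC, using the shake flask method, measured as kinetic solubility, with a stated time of 2 h, at pH 7.4 (a higher number here means a more soluble compound, a lower number a less soluble compound), compound 1 gives < 5000 nM, a limit of the assay.
compound 2 `COc1ccc(-c2c(C)nn3c(NCc4ccccn4)cc(C)nc23)cc1`: in this assay compound 2 gives < 5000 nM, also a limit.
compound 3 `COc1ccc(-c2cnn3c(NCc4ccccn4)cc(C)nc23)cc1`: in this assay compound 3 gives < 5000 nM, again a limit.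

Compound 3 therefore stands only at a limit, with no number of its own; the same holds across the series, as the limit of < 5000 nM in this assay, at which 3 of the 3 values shown sit, shows. Among the measured compounds shown here, the single measured step, a step that the two limits leave unreadable from compound 2 to compound 3, hydrogen in place of methyl on an aromatic carbon, is unreadable because both ends sit at the limit. Compound 4 `Cc1cc(NCc2ccccn2)n2ncc(-c3ccncc3)c2n1` differs from compound 3 by pyridin-4-yl in place of 4-methoxyphenyl on an aromatic carbon. For the measured compounds named here, no measured step bears on this change, so the data give neither direction nor size for this assay; the only guide is that every value so far is a limit. Compound 4 is estimated at 6000 nM, within a range of 1500 nM to 30000 nM, with a real chance that it is again reported only as a limit. The step expected is an at least 1.2-fold higher number from compound 3 to compound 4 (0.07 log units; that floor lies within the scatter), an estimate resting on the limits alone.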

Compound 4, solubility: 161000 nM
Compound 4: middle estimate off by 27-fold (1.43 log units), on the low side; measured number above the stated range.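

Among the compounds shown here, at this position, on an aromatic carbon of the five-membered aromatic ring, pyridin-4-yl in place of 4-methoxyphenyl gives an at least 32-fold higher number from compound 3 to compound 4 (1.50 log units; beyond the scatter), the only step with a readable size in this assay. Compound 4 alone carries a number of its own, while the other compounds all rest at one value: the limit of < 5000 nM in this assay, at which 3 of the 4 values shown sit. On these data alone, compound 3 gives < 5000 nM, a limit of the assay, so the step is a floor and its full size stays unknown.

As far as these compounds go, whether the ring nitrogen of pyridin-4-yl is what matters remains open, and a pyridin-3-yl group or a phenyl ring carrying a carboxylic acid at this carbon would help to separate that from the loss of the methoxy group. Also open, from the compounds shown here alone, is whether the same exchange reads alike on the core of compound 2, which keeps its methyl.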